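The source may report more compounds than this note shows. Statements on the series, on what has been measured and on what is new or still open speak of the compounds shown alone.

Measured so far in a functional assay on HeLa cells (Homo sapiens) for cytotoxicity, read by MTT assay; a lower number here means a stronger inhibitor, a higher number a weaker inhibitor:

Compound 1, `CC(C)C1=CC2=C(C(=O)C1=O)[C@]13CO[C@H]2C[C@H]1C(C)(C)C[C@H](O)C3`, gives > 10000 nM.
Compound 2, `CC(C)C1=C[C@@]23Oc4c(C(C)C)cc5c(c4O[C@]2(C(=O)C1=O)[C@]12CO[C@@H]3C[C@H]1C(C)(C)C[C@H](O)C2)[C@]12CO[C@@H]5C[C@H]1C(C)(C)C[C@H](O)C2`, gives > 10000 nM.

Both numbers are limits of this assay, not measured values. The value of compound 1 is a limit. Going by the values given here, the value of compound 2 is likewise a limit, so compound 2 stands at the edge of what this assay can report, and the one other value shown sits at the same edge, as the limit of > 10000 nM in this assay, at which 2 of the 2 values shown sit, records. Among the compounds with values here, no step between two measured compounds is available, so nothing shows how much a change in structure moves the read-out here.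

Compound 3, `CC(C)C1=C[C@]23Oc4c(C(C)C)cc5c(c4O[C@@]2(C(=O)C1=O)[C@]12CO[C@@H]3C[C@H]1C(C)(C)C[C@H](O)C2)[C@]12CO[C@@H]5C[C@H]1C(C)(C)C[C@H](O)C2`, has not been measured. It differs from compound 2 in this way: the two compounds have the same atoms and bonds and differ only in configuration as drawn: 2 of 10 stereo elements differ; a stereocentre at a saturated ring carbon is drawn S in compound 2 and R in compound 3; a stereocentre at a saturated ring carbon is drawn R in compound 2 and S in compound 3.

With both known values resting at a limit and the atoms and bonds unchanged, no step beyond the scatter is expected in either direction for the change from compound 2 to compound 3; the estimated step that the limit leaves unreadable from compound 2 to compound 3 expresses this. Compound 3 is therefore expected to give about 15000 nM in this assay, within a range from 7000 nM to 40000 nM, most likely again as a limit rather than a number.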

Compound 3, half-maximal inhibitory concentration: 5200 nM
Beside the measured number, compound 3's estimate is 2.9-fold (0.46 log units) above it; the whole stated range lies above it.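

In this assay, changing the configuration at two saturated ring carbons, with the atoms and bonds left untouched, gives an at least 1.9-fold lower number from compound 2 to compound 3 (0.28 log units; that floor lies within the scatter). Going by these compounds alone, compound 3 is the first compound in this set to return a number rather than a limit, and what separates it from compound 2 is stated plainly: the fact that compounds 2 and 3 differ only in the configuration as drawn. The value of compound 2 is a limit, so the step has only a floor, that floor lies within the scatter, and the true size of the step cannot be read: the limit of > 10000 nM in this assay, at which 2 of the 3 values shown sit.

As far as these compounds go, the two stereocentres change together in this pair, so it stays open whether one of them alone would accompany the same shift or whether both are needed. It also stays open how the value of compound 3 in this assay would respond if an amine or a carboxylic acid stood in place of the hydroxyl group, as the compounds shown all carry that hydroxyl and none of these other groups.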